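Lipophilicity notes on a carboxylic acid hydrazide series

A few compounds are considered here, and "the series" means these few. Any claim that something is new, unique, unknown or untested is made for them only; others in the source may bear on it.

Measured compounds:
compound 1 `CC(=N)Nc1cccc(C(=O)NNC(=O)CC(CC(=O)O)c2ccc(F)cc2)c1` — 1.6
compound 2 `CC(=N)Nc1cccc(C(=O)NNC(=O)CC(CC(=O)O)c2cc(Cl)cc(Cl)c2)c1` — 2.55

In a physicochemical assay for lipophilicity (on this read-out higher numbers stand for higher lipophilicity and lower numbers for lower lipophilicity), compound 1 gives 1.6 and stands lowest of the two numbers shown; its nearest neighbour is compound 2, reached by a number 0.95 log units higher from compound 1 to compound 2 (beyond the scatter). Compound 3 `CC(=N)Nc1cccc(C(=O)NNC(=O)CC(CC(=O)O)c2ccc(-c3ccccc3)cc2)c1` has not yet been measured. It differs from compound 1 in one place: phenyl in place of fluoro on an aromatic carbon. Among the measured compounds shown here, the only measured step that bears on this change is the one from compound 1 to compound 2, which replaced a 4-fluorophenyl with a 3,5-dichlorophenyl and gave a modest rise in this assay, a number 0.95 log units higher from compound 1 to compound 2 (beyond the scatter). A phenyl entering in place of fluoro is a larger addition of carbon than two chlorines, so a step upward in this assay at least as large is expected for compound 3, a number 1.50 log units higher from compound 1 to compound 3 (beyond the scatter). The estimate for compound 3 in this assay is therefore 3.1, with a range from 2.6 to 3.7.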

Compound 3, partition coefficient: 3.11
Estimate against measurement, compound 3: 0.01 log units below, within the range that was stated.
By their numbers in this assay, from the lowest: compound 1; then compound 2; then compound 3.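

Replacing fluoro with phenyl on an aromatic carbon, para to a large group, gives in this assay a large step, a number 1.51 log units higher from compound 1 to compound 3 (beyond the scatter), the only step shown that isolates a change at this one position. Compound 2 differs from compound 1 by a different substitution pattern on the same ring, so it could not show that this single carbon accepts a whole six-membered aromatic ring with this result. No independent data bear on the reason for the step.

From the compounds shown here alone, what remains open is whether the rise follows from the six added carbons or from the aromatic ring itself, which a cyclohexyl group at this carbon would separate. An amine or a methoxy group at the same carbon would show how far the read-out falls or rises with other replacements for fluoro.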